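A few compounds are considered here, and "the series" means these few. Any claim that something is new, unique, unknown or untested is made for them only; others in the source may bear on it.

In a functional assay on A-375 cells (Homo sapiens) for cytotoxicity, read by CCK-8 assay, with a stated time of 24 h (on this read-out lower numbers stand for stronger inhibition and higher numbers for weaker inhibition), compound 1 `COc1cccc(-c2nc(N)c(Oc3ccccc3OC)c(Cl)n2)c1` gives 24600 nM, and compound 2 `COc1ccccc1Oc1c(N)nc(-c2cccc(Cl)c2)nc1Cl` gives 38300 nM. Going by the values given here, these are the only two measurements so far, and they lie within the usual scatter of each other, so compound 2 cannot be told apart from compound 1 on these numbers. Compound 3 `COc1ccccc1Oc1c(N)nc(-c2cccc(I)c2)nc1Cl` has not been measured yet. It is compound 2 with a single substitution: iodo in place of chloro on an aromatic carbon. Among the compounds with values here, only one measured step offers any guidance. It is also an exchange of one group on an aromatic carbon, chloro in place of methoxy, and it amounts to a 1.6-fold higher number from compound 1 to compound 2 (0.19 log units; within the scatter). Within the data shown here, with this single small step as the only evidence, no change beyond the scatter is expected in this assay, and the data favour no direction. The estimate therefore means a 1.2-fold lower number from compound 2 to compound 3 (0.06 log units; within the scatter), an expected step that stays within the scatter. For compound 3 the expected value is 33000 nM, with an estimated range from 14000 nM to 75000 nM.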

Compound 3, half-maximal inhibitory concentration: 2200 nM
Compound 3: the middle estimate sits 15-fold (1.18 log units) above what was measured; measured number outside the range, below it.
By their numbers in this assay, from the lowest: compound 3; then compounds 1 and 2 (each within the scatter of the next).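

The earlier pair made this place on the ring look insensitive, but in this assay going from 3-chlorophenyl to 3-iodophenyl gives a 17-fold lower number from compound 2 to compound 3 (1.24 log units; beyond the scatter), so exchanging one halogen atom for another is enough to move the number well beyond the scatter. The comparison with methoxy on the same aromatic carbon points the same way, with an 11-fold lower number from compound 1 to compound 3 (1.05 log units; beyond the scatter), so among these three compounds iodo stands apart, while chloro and methoxy cannot be told apart. The change is therefore a sharp one at a single atom, and the data at hand offer no explanation for why iodo behaves so differently from chloro here.

Three compounds cannot show whether this strong result belongs to iodo alone or would also appear with bromo, with a trifluoromethyl group or with an ethynyl group on the same carbon. On these data alone, it also remains open whether an amine or a carboxylic acid would be accepted there, and whether iodo would have a similar effect if the rest of the shared core were changed.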